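Substituents on the aromatic nitrogen: compound 3 to compound 4

The source may report more compounds than this note shows. Statements on the series, on what has been measured and on what is new or still open speak of the compounds shown alone.

Measured in an assay on CHO cells for displacement of a labelled ligand from Substance-P receptor (Homo sapiens) (a lower number here means a stronger inhibitor, a higher number a weaker inhibitor), so far:
- compound 1 `COc1ccccc1N1CCN(C(=O)CCc2c(-c3ccccc3)[nH]c3ccc(C)cc23)CC1`: 6.1 nM
- compound 2 `COc1ccccc1N1CCN(C(=O)CCc2c(-c3ccc(Cl)cc3)[nH]c3ccc(Cl)cc23)CC1`: 0.89 nM
- compound 3 `COc1ccccc1N1CCN(C(=O)CCc2c(-c3ccc(Cl)cc3)n(Cc3ccccc3)c3ccc(Cl)cc23)CC1`: 96 nM

Compound 3 gives the highest number of the three. Among the measured compounds shown here, the gap to compound 2 is the step of a 110-fold higher number from compound 2 to compound 3 (2.03 log units; beyond the scatter), the only change in this set made on the aromatic nitrogen, and it is large and beyond the scatter. Compound 1 and compound 2, which both carry hydrogen on that nitrogen, sit well below compound 3.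

Compound 4 `COC(=O)Cn1c(-c2ccc(Cl)cc2)c(CCC(=O)N2CCN(c3ccccc3OC)CC2)c2cc(Cl)ccc21` keeps the substituted aromatic nitrogen of compound 3 and differs from it in one place: methoxycarbonyl in place of phenyl on a saturated chain carbon bound to an aromatic nitrogen. For the measured compounds named here, no measured pair covers this exchange. What is known is only that placing benzyl on the aromatic nitrogen, from compound 2 to compound 3, cost heavily; whether a (methoxycarbonyl)methyl group on the same nitrogen costs as much, less, or more cannot be read from these three compounds.

In this assay compound 4 is therefore expected to stay in the region of compound 3, with a step of a 1.6-fold lower number from compound 3 to compound 4 (0.20 log units; within the scatter) that may well fall within the scatter; a wide range is kept. The estimate for compound 4 is 60 nM, between 15 nM and 250 nM.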

Compound 4, half-maximal inhibitory concentration: 15 nM
For compound 4 the middle estimate is 4.0-fold (0.60 log units) above the measured one; the range from low to high includes it.
By their numbers in this assay, from the lowest: compound 2; then compound 1; then compound 4; then compound 3.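

The exchange of phenyl for methoxycarbonyl on a saturated chain carbon bound to an aromatic nitrogen gives a 6.4-fold lower number from compound 3 to compound 4 (0.81 log units; beyond the scatter) in this assay and shows that the loss seen on substituting this nitrogen depends on the group placed there. Substitution still carries a cost: (methoxycarbonyl)methyl in place of hydrogen gives a 17-fold higher number from compound 2 to compound 4 (1.23 log units; beyond the scatter) and, like benzyl with a 110-fold higher number from compound 2 to compound 3 (2.03 log units; beyond the scatter), does not return to the level of compound 2. No measured data explain why the two substituents differ.

The step exchanges a six-membered aromatic ring for a group with two hydrogen-bond acceptors, and these compounds do not separate the loss of the ring from the entry of the ester. From the compounds shown here alone, it also remains open whether a carboxylic acid or a primary amide in place of the methyl ester, or a longer chain carrying the ester on the same nitrogen, would bring the number closer to that of compound 2.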